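This account rests on a few compounds, and the source may have more. Where it says the series, first, only, none or still open, it means among the compounds named here.

Measured so far in an ADME assay on Vero cells (Chlorocebus sabaeus) for cytotoxicity, read by MTT assay, with a stated time of 72 h; a higher number here means that more compound is needed for the effect, a lower number that less compound is needed:
Compound 1 `O=C(Nc1nc(-c2ccccn2)cs1)c1ccccc1F`: "not determined" (no result reported)
Compound 2 `O=C(Nc1nc(-c2ccccn2)cs1)c1cccc(F)c1`: 1200 nM

Within the data shown here, compound 2, at 1200 nM, holds the only number, so it cannot yet be called high or low against any neighbour. Compound 1 offers no comparison, as its entry has no result.

Compound 3 `O=C(Nc1nc(-c2ccccn2)cs1)c1cccc(F)c1F` differs from compound 2 as follows: fluoro in place of hydrogen on an aromatic carbon. The new fluoro sits ortho to a fluoro group and ortho to a large group.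

Among the measured compounds shown here, no measured pair shows what this kind of change does in this assay. Without such evidence, no shift beyond the scatter is expected in either direction, and compound 2 at 1200 nM serves as the only anchor. The expected change is a 1.2-fold lower number from compound 2 to compound 3 (0.08 log units; within the scatter), an estimate that stays within the usual scatter. Compound 3 is estimated at 1000 nM, with an expected range of 350 nM to 3000 nM.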

Compound 3, half-maximal effective concentration: 7200 nM
For compound 3 the middle estimate is 7.2-fold (0.86 log units) below the measured one, outside the stated range (above it).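

In this assay, among these compounds, the first readable step is a 6.0-fold higher number from compound 2 to compound 3 (0.78 log units; beyond the scatter), and it comes from fluoro in place of hydrogen on an aromatic carbon, ortho to a fluoro group and ortho to a large group. Among the compounds shown here, this position is therefore not silent in this assay: the change lies beyond the scatter and moves the number towards more compound being needed for the effect, which the earlier entries could not show, as they offered no measured pair. No measurement at hand accounts for the size of this step, so it stands as an observation without an explanation.

On these data alone, compound 1 carries its fluoro at another place on the ring and has no result, so any step involving it cannot be read, and it remains open whether the shift depends on the fluoro already present in compound 2 or would appear on the ring without it. The compounds shown also leave open whether another group at the same carbon, such as chloro, methoxy or an amine, would move the number in the same direction.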